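Swapping the aromatic group on a sulfonamide nitrogen

This account rests on a few compounds, and the source may have more. Where it says the series, first, only, none or still open, it means among the compounds named here.

Compound 1 `CCc1ccccc1NS(=O)(=O)c1ccc(N2CCNC2=O)cc1` gives 350 nM
Compound 2 `O=C1NCCN1c1ccc(S(=O)(=O)Nc2cccc(Cl)c2)cc1` gives 79 nM

Both numbers come from a functional assay on MCF7 cells (Homo sapiens) for antiproliferative activity, read by sulforhodamine B assay, with a stated time of 48 h; on this read-out higher numbers stand for weaker inhibition and lower numbers for stronger inhibition. Compound 2 holds the lower of the two numbers, which makes it the stronger inhibitor of this pair, and the gap to compound 1 lies beyond the scatter. The next compound, compound 3 `COc1ccccc1NS(=O)(=O)c1ccc(N2CCNC2=O)cc1`, keeps the shared core and changes one group: 2-methoxyphenyl in place of 3-chlorophenyl on a sulfonamide nitrogen.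

For the measured compounds named here, only one measured step bears on this change. It is a 4.4-fold lower number from compound 1 to compound 2 (0.65 log units; beyond the scatter), a modest step at the same place, where 3-chlorophenyl took the place of 2-ethylphenyl. Compound 3 gives up that same 3-chlorophenyl, and its new group carries the same number in its name as the 2-ethylphenyl of compound 1. A single step is thin evidence, and a methoxy group has not yet been measured here, so the range stays wide. The expected change runs toward a higher number, of about the same size as that earlier step: a 3.5-fold higher number from compound 2 to compound 3 (0.55 log units; beyond the scatter) is the estimate. For compound 3 the expected value is 280 nM, with an estimated range from 90 nM to 800 nM.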

Compound 3, half-maximal inhibitory concentration: 770 nM
Beside the measured number, compound 3's estimate is 2.8-fold (0.44 log units) below it; low and high end bracket the measured number.
By their numbers in this assay, from the lowest: compound 2; then compound 1; then compound 3.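

Leaving the 3-chlorophenyl costs more than the earlier step hinted: in this assay the change to 2-methoxyphenyl gives the widest step yet seen on this sulfonamide nitrogen (a 9.7-fold higher number from compound 2 to compound 3 (0.99 log units; beyond the scatter)). The new compound also allows a different comparison, methoxy in place of ethyl on an aromatic carbon, and that swap too moves the number up (a 2.2-fold higher number from compound 1 to compound 3 (0.34 log units; beyond the scatter)), so the 2-ethylphenyl of compound 1 and the 2-methoxyphenyl of compound 3 do not behave alike, and among these three compounds the 3-chlorophenyl of compound 2 keeps the lowest number. No measurement at hand explains why these groups differ.

On these data alone, what stays open is whether the lower number of compound 2 follows the chlorine itself or the place of the group on the ring, and a 3-methoxyphenyl or a 2-chlorophenyl on the same nitrogen would separate these two readings. As far as these compounds go, how this position would respond to a quite different group on that aromatic ring, such as an amine or a carboxylic acid, also remains unknown from these compounds.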